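A few compounds are considered here, and "the series" means these few. Any claim that something is new, unique, unknown or untested is made for them only; others in the source may bear on it.

Measured compounds in an assay for inhibition of kynurenine 3-monooxygenase (Rattus norvegicus); a lower number here means a stronger inhibitor, a higher number a weaker inhibitor:
compound 1 `COC(=O)C(=O)/C=C(\O)c1cccc(Cl)c1` gives 1900 nM
compound 2 `COC(=O)C(=O)/C=C(\O)c1ccc(F)c(F)c1` gives 3300 nM
compound 3 `COC(=O)C(=O)/C=C(\O)c1ccc(F)c(Cl)c1` gives 2600 nM

Compound 3 stands second highest of the three numbers; its nearest neighbour is compound 2, its furthest compound 1, and both gaps are within the scatter, so the three compounds cannot be ranked against each other on these data. The two measured steps, a 1.4-fold higher number from compound 1 to compound 3 (0.14 log units; within the scatter) and a 1.3-fold lower number from compound 2 to compound 3 (0.10 log units; within the scatter), both concern the halogen pattern on the aromatic ring and both stay within the scatter.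

Compound 4 `O=C(O)C(=O)/C=C(\O)c1ccc(F)c(Cl)c1` differs from compound 3 by hydrogen in place of methyl on an oxygen next to a carbonyl group: methoxycarbonyl to carboxy. Among the measured compounds shown here, no measured step touches this part of the core; the aromatic-ring steps say nothing about it, and the series offers no precedent for the size or direction of such a change. The expectation for compound 4 therefore rests on compound 3 alone, with a wide range: the step of a 2.2-fold lower number from compound 3 to compound 4 (0.34 log units; beyond the scatter) is an estimate without a measured anchor. In this assay compound 4 is expected near 1200 nM, between 200 nM and 6000 nM.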

Compound 4, half-maximal inhibitory concentration: 270 nM
Compound 4: middle estimate off by 4.4-fold (0.65 log units), on the high side; the range from low to high includes it.
By their numbers in this assay, from the lowest: compound 4; then compounds 1, 3 and 2 (each within the scatter of the next).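

In this assay, methoxycarbonyl to carboxy on the shared core gives a 9.6-fold lower number from compound 3 to compound 4 (0.98 log units; beyond the scatter) and is the only step shown that lies beyond the scatter, whereas the two halogen steps on the aromatic ring stay within it. The oxygen next to a carbonyl group is therefore a place where a single change moves the number clearly, and replacing methyl with hydrogen moves it downward with the halogen pattern of compound 3. No measured evidence bears on why this step occurs.

Going by these compounds, whether the lower number needs the carboxy group itself remains open, and an ethyl ester, a primary amide or a hydroxamic acid in its place would test that. On these data alone, it is also open whether the same change carries over to the halogen patterns of compound 1 and compound 2.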